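Ring methyl on compound 1: expected stomach inhibition

The compounds below may be only part of what the source reports. "The series", "measured", "known", "first", "only" and "open" are said of these compounds alone.

For the measured compounds named here, compound 1 `CC(Cn1ncccc1=O)C(=N)S` is the reference point of the two compounds measured so far. In a functional assay on the whole organism (stomach) for inhibition, with Rattus norvegicus as the target, at a dose of 100 mg/kg by the intraduodenal route (a higher number here means more inhibition at the dose given (going by the name of the read-out), a lower number less inhibition), compound 1 gives 40.3%, the highest of the two numbers in hand. Compound 2 `N=C(S)CCn1ncccc1=O` gives 28.8% in this assay; the step of a number 11.5 percentage points lower from compound 1 to compound 2 (beyond the scatter) came with hydrogen in place of methyl on a saturated chain carbon bound to a carbon with a double bond to nitrogen and a saturated chain carbon.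

Compound 3 `Cc1ccc(=O)n(CC(C)C(=N)S)n1` differs from compound 1 by methyl in place of hydrogen on an aromatic carbon. Going by the values given here, no measured step concerns the six-membered aromatic ring of the shared core; the single step in hand concerns the chain methyl and so does not bear directly on the change to compound 3. With nothing pointing either way, no step beyond the scatter is expected in this assay from this change, and the step of a number 0.3 percentage points lower from compound 1 to compound 3 (within the scatter) is an estimate of essentially no change. Compound 3 is therefore expected to give about 40% in this assay, within a range from 22% to 58%.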

Compound 3, a percentage reported as inhibition, in the whole organism at one dose (the size of the read-out at that dose, not a potency): 30.2%
Compound 3: middle estimate off by 9.8 percentage points, on the high side; the measured number falls inside the stated range.
By their numbers in this assay, from the lowest: compounds 2 and 3 (each within the scatter of the next); then compound 1.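

In this assay, for the compounds shown here, this aromatic carbon, next to the ring nitrogen, is not a silent place on the shared core: methyl in place of hydrogen there gives a number 10.1 percentage points lower from compound 1 to compound 3 (beyond the scatter), the first reading of any change on the ring itself. Set beside a number 11.5 percentage points lower from compound 1 to compound 2 (beyond the scatter), which concerns the chain methyl, this shows that the place of a methyl matters among these three compounds, since the chain methyl goes with the higher number and the ring methyl with the lower. Nothing in hand gives a measured property that bears on this result.

From the compounds shown here alone, it remains open whether the lower number is particular to methyl or would also follow a different group on the same aromatic carbon, such as chlorine, methoxy or phenyl, and whether the other ring carbons respond in the same way. Also open, going by these compounds, is how the ring methyl reads on the chain of compound 2, and, as each number comes from a single dose, whether the step would hold at other doses.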